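This account rests on a few compounds, and the source may have more. Where it says the series, first, only, none or still open, it means among the compounds named here.

Read-outs in an ADME assay on HepG2 2.2.15 cells (Homo sapiens) for cytotoxicity; on this read-out higher numbers stand for lower toxicity in this test and lower numbers for higher toxicity in this test:
Compound 1 `O=c1[nH]c2ccc(Cl)cc2c(-c2ccccc2Cl)c1CCO`: 380000 nM
Compound 2 `CC(=O)OCCc1c(-c2ccccc2Cl)c2cc(Cl)ccc2[nH]c1=O`: 27000 nM
Compound 3 `CCCCCCCC(=O)OCCc1c(-c2ccccc2Cl)c2cc(Cl)ccc2[nH]c1=O`: 78000 nM

On these numbers compound 3 is the second highest of the three. Its nearest neighbour is reached through a 2.9-fold higher number from compound 2 to compound 3 (0.46 log units; beyond the scatter), and its furthest through a 4.9-fold lower number from compound 1 to compound 3 (0.69 log units; beyond the scatter).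

The next compound in the account is compound 4 `O=C(O)CCCC(=O)OCCc1c(-c2ccccc2Cl)c2cc(Cl)ccc2[nH]c1=O`. The structural change is carboxy in place of butyl on a saturated chain carbon, three bonds along the chain from a carbonyl carbon.

Within the data shown here, no measured step makes this replacement, so the evidence is indirect. Replacing the hydrogen on the oxygen gave a 14-fold lower number from compound 1 to compound 2 (1.15 log units; beyond the scatter), a large step, and a 4.9-fold lower number from compound 1 to compound 3 (0.69 log units; beyond the scatter), a modest one. Changing the chain itself gave a 2.9-fold higher number from compound 2 to compound 3 (0.46 log units; beyond the scatter), also modest. The chain step is the closest guide, and it suggests that compound 4 should stay with the two compounds carrying an acyl chain rather than return to compound 1. The expected change is small, with no step beyond the scatter anticipated and only a slight lean upward: a 1.4-fold higher number from compound 3 to compound 4 (0.15 log units; within the scatter). In this assay the estimate for compound 4 is 110000 nM, with the expected range running from 35000 nM to 350000 nM.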

Compound 4, half-maximal cytotoxic concentration: 110000 nM
The estimate for compound 4 equals the measured number at the digits printed, and the stated range covers the measured number.
By their numbers in this assay, from the lowest: compound 2; then compounds 3 and 4 (each within the scatter of the next); then compound 1.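

In this assay, carboxy in place of butyl on a saturated chain carbon, three bonds along the chain from a carbonyl carbon, gave a 1.4-fold higher number from compound 3 to compound 4 (0.15 log units; within the scatter), so this read-out did not separate the 3-carboxypropyl chain from the heptyl chain at this position. Set against the acetyl compound, the 2-carboxyethyl change gave a 4.1-fold higher number from compound 2 to compound 4 (0.61 log units; beyond the scatter), and the (3-carboxypropyl)carbonyl group in place of hydrogen on the oxygen gave a 3.5-fold lower number from compound 1 to compound 4 (0.54 log units; beyond the scatter) relative to the parent alcohol. The carboxy-ended chain therefore joins the picture set by the earlier compounds: all three acyl groups on that oxygen stand below compound 1, both longer chains stand above compound 2, and none of the compounds shown goes against either pattern.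

The compounds shown leave open whether an amine at the end of the chain, or an ether or a carbamate on that oxygen in place of the acyl link, would stay with compound 3 and compound 4 or move towards compound 1 or compound 2. Nothing given here bears on the reason for any of these steps.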